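A few compounds are considered here, and "the series" means these few. Any claim that something is new, unique, unknown or untested is made for them only; others in the source may bear on it.

Working notes on the series. Compound 1 `COc1ccc(CNc2nc(SC)nc3ccccc23)cc1`, compound 2 `CCCCC[Se]c1nc(NCc2ccccc2)c2ccccc2n1` and compound 3 `Sc1nc(NCc2ccccc2)c2ccccc2n1` share one core and were read in a functional assay on CCRF-CEM cells (Homo sapiens) for cytotoxicity, read by MTT assay, with a stated time of 72 h; a higher number here means that more compound is tolerated, a lower number that less compound is tolerated. In this assay compound 1 gives only a limit, > 100000 nM. In this assay compound 2 likewise gives only a limit, > 100000 nM. In this assay compound 3 gives only a limit, > 100000 nM. Within the data shown here, compound 3 thus stands at the limit of > 100000 nM in this assay, at which 3 of the 3 values shown sit, with no number of its own, and the one single-site step that reaches it, a step that the two limits leave unreadable from compound 2 to compound 3, cannot be sized from the two limits on either side of it.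

Compound 4 `CSc1nc(NCc2ccccc2)c2ccccc2n1` is not yet measured in this assay. It differs from compound 3 by methyl in place of hydrogen on a sulfur. Among the measured compounds shown here, no measured step in the set bears on this change with a readable size; all three values shown sit at the same limit. The expectation for compound 4 is therefore no readable step, a number no higher from compound 3 to compound 4 (the limit leaves the size open), with a further limit the most likely outcome. Compound 4 is estimated at 100000 nM, in a range from 40000 nM to 300000 nM.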

Compound 4, concentration lethal to 50% of the cells: > 100000 nM
Compound 4: only a limit was reported (the forecaster's own chance of this, stated with the estimate: 85%); the middle value lies on the limit itself.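

The steps from compound 1, compound 2 and compound 3 to compound 4 cannot be read, as each joins two limits: the limit of > 100000 nM in this assay, at which 4 of the 4 values shown sit. The compounds shown leave open whether any change on the shared core gives a number of its own in this assay.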